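The source may report more compounds than this note shows. Statements on the series, on what has been measured and on what is new or still open speak of the compounds shown alone.

Measured compounds:

- compound 1, `COc1cc(-c2nnc(SCc3cccc(Br)c3)o2)ccc1O`: 48100 nM
- compound 2, `COc1cc(-c2nnc(SCc3c(F)cccc3F)o2)ccc1O`: 10100 nM
- compound 3, `COc1cc(-c2nnc(SCc3cccc(Cl)c3)o2)ccc1O`: 8290 nM

The read-out is a functional assay on cells (T-cell, Mus musculus, strain BALB/c) for inhibition, read by MTT assay, with stated times of 24 h and 72 h; a higher number here means a weaker inhibitor, a lower number a stronger inhibitor. Compound 3 gives the lowest number of the three. Its nearest neighbour is compound 2, and the gap between them, a 1.2-fold lower number from compound 2 to compound 3 (0.09 log units; within the scatter), does not allow any ranking of the two. Among the measured compounds shown here, the gap to compound 1 is larger, a 5.8-fold lower number from compound 1 to compound 3 (0.76 log units; beyond the scatter), and that step is the one clean halogen swap in the set: chloro in place of bromo on an aromatic carbon.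

Compound 4, `COc1cc(-c2nnc(SCc3ccccc3Br)o2)ccc1O`, is not yet measured. It differs from compound 3 as follows: 2-bromophenyl in place of 3-chlorophenyl on a saturated chain carbon bound to a sulfur. Two things change at once: the halogen (back to bromo, as in compound 1) and the position on the ring. The measured steps that bear on this are a 5.8-fold lower number from compound 1 to compound 3 (0.76 log units; beyond the scatter), which says that bromo in place of chloro at the same position gave a substantially higher number, and a 4.8-fold lower number from compound 1 to compound 2 (0.68 log units; beyond the scatter) together with a 1.2-fold lower number from compound 2 to compound 3 (0.09 log units; within the scatter), which show that a different ring substitution pattern can sit close to compound 3. For the measured compounds named here, no measured pair isolates the move of a single halogen around the ring.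

Weighting the halogen swap, compound 4 is expected to give a higher number than compound 3, estimated as 25000 nM with a range of 8000 nM to 80000 nM, meaning an expected step of a 3.0-fold higher number from compound 3 to compound 4 (0.48 log units; beyond the scatter).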

Compound 4, half-maximal inhibitory concentration: 17800 nM
The estimate for compound 4 lay 1.4-fold (0.15 log units) above the measured number; low and high end bracket the measured number.
By their numbers in this assay, from the lowest: compounds 3, 2 and 4 (each within the scatter of the next, the first and the last beyond it); then compound 1.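

Among the compounds shown here, the pair of compound 1 and compound 4 is the first to isolate where a single halogen sits on the ring: in this assay, 2-bromophenyl in place of 3-bromophenyl on the saturated chain carbon bound to the sulfur gives a 2.7-fold lower number from compound 1 to compound 4 (0.43 log units; beyond the scatter) and shows that the high number of compound 1 does not follow from bromo alone. The remaining gap, a 2.1-fold higher number from compound 3 to compound 4 (0.33 log units; beyond the scatter) for the 2-bromophenyl group against the 3-chlorophenyl group, combines a change of halogen with a change of ring position and cannot be assigned to either, while a 1.8-fold higher number from compound 2 to compound 4 (0.25 log units; within the scatter) leaves the 2-bromophenyl and 2,6-difluorophenyl groups unranked. No measurement at hand accounts for these differences.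

Going by these compounds, whether the dependence on ring position seen with bromo also holds for chloro remains open, as the comparison would need 2-chlorophenyl set against 3-chlorophenyl. Equally open is how this position responds to the plain unsubstituted phenyl group, to a phenyl group carrying an amine or a carboxylic acid, or to a longer chain between the sulfur and the ring, since every compound shown has a halogenated phenyl group on a single chain carbon.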